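The compounds below may be only part of what the source reports. "The series", "measured", "known", "first", "only" and "open" are said of these compounds alone.

Measured so far in a functional assay on BV-2 cells (Mus musculus) for inhibition, read by Griess assay, with a stated time of 24 h; a lower number here means a stronger inhibitor, a higher number a weaker inhibitor (three compounds)
- compound 1 `COc1ccc(Br)cc1-c1cc(CO)on1` gives > 200000 nM
- compound 2 `C=CCc1ccc(OC)c(-c2cc(CO)on2)c1` gives > 200000 nM
- compound 3 `C=CCc1ccc(O)c(-c2cc(CCC)on2)c1` gives > 200000 nM

Each of these entries is a limit of the assay and not a number. Compound 1 therefore stands only on a limit (> 200000 nM) and has no measured potency to serve as a baseline. Within the data shown here, the series so far is summed up by one observation (the limit of > 200000 nM in this assay, at which 3 of the 3 values shown sit), so no compound can be ranked against another.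

Compound 4 `COc1ccc(Br)cc1-c1cc(COCc2ccccc2)on1` is the next to be read. Its change from compound 1 is benzyl in place of hydrogen on an oxygen on a saturated carbon. Among the measured compounds shown here, the only measured step (a step that the two limits leave unreadable from compound 1 to compound 2) concerns allyl in place of bromo on an aromatic carbon, a different place, and it has no readable size. For the measured compounds named here, no measured step therefore sizes the benzyl change.

The starting point is compound 1 (> 200000 nM), a limit, so any number read for compound 4 in this assay would mean a stronger inhibitor. Another reading at the limit remains a real possibility.

The expected step, towards stronger inhibition and of poorly known size, is (an at least 2.0-fold lower number from compound 1 to compound 4 (0.30 log units; that floor lies within the scatter)). The estimate for compound 4 is 100000 nM (expected range 25000 nM to 300000 nM).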

Compound 4, half-maximal inhibitory concentration: > 200000 nM
Compound 4 ended at the assay's limit; the forecaster's own chance of this, stated with the estimate: 55%; at least 2.0-fold (0.30 log units) between middle value and limit.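

Compound 4, like compound 1, stands only on a limit of this assay and not on a number, so no step can be read between them. The compounds shown leave open whether any change to the shared core gives a measurable potency, since the series still rests on one observation: the limit of > 200000 nM in this assay, at which 4 of the 4 values shown sit.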